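This account rests on a few compounds, and the source may have more. Where it says the series, first, only, none or still open, it means among the compounds named here.

Compound 1, `COc1cc(-n2ncnc2-c2ccc(Cl)cc2)cc(OC)c1OC`, and compound 2, `COc1cc(-c2ncnn2-c2ccc(Cl)c(Cl)c2)cc(OC)c1OC`, share one core and differ only in the substitution of the outer phenyl ring. In a functional assay on HL-60 cells (Homo sapiens) for antiproliferative activity, read by MTT assay, with a stated time of 72 h (a higher number here means a weaker inhibitor, a lower number a stronger inhibitor), compound 1 gives > 10000 nM, which is a limit of the assay and not a measured number. Compound 2 likewise stops at > 10000 nM, again a limit rather than a number. Both values sit at the limit of > 10000 nM in this assay, at which 2 of the 2 values shown sit, so compound 1 stands at the weak end of what the assay can report, without a number of its own to compare against.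

Compound 3, `COc1cc(-n2ncnc2-c2ccc(SC)cc2)cc(OC)c1OC`, differs from compound 1 in a single place: methylsulfanyl in place of chloro on an aromatic carbon. Among the compounds with values here, no step between two measured compounds is available to show how this assay responds to such a change, so the step from compound 1 to compound 3 cannot be taken from the data. With both measured compounds at the limit, the plain expectation is that compound 3 stays near it. Compound 3 is estimated at 10000 nM, with a range of 2500 nM to 40000 nM. That estimate means a number no higher from compound 1 to compound 3 (the limit leaves the size open) in this assay, no change beyond the scatter.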

Compound 3, half-maximal inhibitory concentration: 500 nM
Compound 3: middle estimate off by 20-fold (1.30 log units), on the high side; measured number outside the range, below it.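

Exchanging chloro for methylsulfanyl on an aromatic carbon of the outer phenyl ring, with the rest of the molecule unchanged, is a change in one place, and in this assay it produces an at least 20-fold lower number from compound 1 to compound 3 (1.30 log units; beyond the scatter). This shows that the assay is not indifferent to the group at this position, which is para to a large group: with the shared core held constant, the group here separates a compound with a measured number from one that stops at the limit of the assay. Compound 3 is the only compound shown with a number of its own, so it gives the series its first measured reference point: the limit of > 10000 nM in this assay, at which 2 of the 3 values shown sit.

The compounds shown leave open how large the step really is and whether the sulfur atom, the added methyl carbon or the two together account for it. Within the data shown here, a methoxy group, an amine or a longer chain such as ethylsulfanyl at the same carbon would help to separate these possibilities and show how far the gain in this assay extends beyond the single methylsulfanyl group.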